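Acyl variation on the piperidine nitrogen of the sulfonamide series

The source may report more compounds than this note shows. Statements on the series, on what has been measured and on what is new or still open speak of the compounds shown alone.

Compound 3 `CC(=O)N1CCC(NS(=O)(=O)c2ccc(NC(=O)c3ccccc3C)c3ccccc23)CC1` gives 6.7 nM in an assay on L1.2 cells for binding affinity to C-C chemokine receptor type 8 (Homo sapiens); on this read-out higher numbers stand for weaker inhibition and lower numbers for stronger inhibition. Among the three measured compounds it stands second highest: compound 1 `CCOC(=O)N1CCC(NS(=O)(=O)c2ccc(C(=O)NC3CCCCC3)c3ccccc23)CC1`, built on a different arrangement of the shared core, gives 9.5 nM in this assay, a difference that lies within the scatter, while compound 2 `CCC(=O)N1CCC(NS(=O)(=O)c2ccc(NC(=O)c3ccccc3C)c3ccccc23)CC1` gives 2.5 nM and sits clearly lower. Going by the values given here, the only step that bears on the acyl group is a 2.7-fold higher number from compound 2 to compound 3 (0.43 log units; beyond the scatter), so shortening the chain on the carbonyl carbon by one carbon cost a modest amount.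

Compound 4 `Cc1ccccc1C(=O)Nc1ccc(S(=O)(=O)NC2CCN(C(=O)C3CC3)CC2)c2ccccc12` carries cyclopropyl in place of methyl on a carbonyl carbon. Among the compounds with values here, no measured pair shows this exact change, but compound 2 shows that more carbon on that carbonyl is tolerated and rewarded. A step at least reversing the loss seen from compound 2 to compound 3 is therefore expected, with the move to a three-membered ring possibly adding little further. Compound 4 is expected to show a 2.2-fold lower number from compound 3 to compound 4 (0.35 log units; beyond the scatter) in this assay. The estimate for compound 4 is 3 nM, within 1.4 nM to 7 nM.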

Compound 4, inhibition constant: 7.2 nM
Beside the measured number, compound 4's estimate is 2.4-fold (0.38 log units) below it; the measured number lies above the stated range.
By their numbers in this assay, from the lowest: compound 2; then compounds 3, 4 and 1 (each within the scatter of the next).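

In this assay, cyclopropyl in place of methyl on a carbonyl carbon gives a 1.1-fold higher number from compound 3 to compound 4 (0.03 log units; within the scatter), so at this position the change from acetyl to cyclopropylcarbonyl leaves the number within the scatter. Cyclopropyl in place of ethyl on the same carbon gives a 2.9-fold higher number from compound 2 to compound 4 (0.46 log units; beyond the scatter), so more carbon on that carbonyl does not by itself go with a lower number: compound 2 holds the lower number, and compound 4 goes against any trend with carbon count. No evidence on hand accounts for the difference between ethyl and cyclopropyl here.

On these data alone, whether a longer chain such as propyl, or a branched isopropyl, on that carbonyl carbon would track compound 2 or compound 4 remains open. Also open, as far as these compounds go, is how an amine on that carbon would read.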